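The compounds below may be only part of what the source reports. "The series", "measured", "known", "first", "only" and "open" are said of these compounds alone.

Compound 1, with the structure `O=C(/C=C/c1ccc([N+](=O)[O-])cc1)Nc1cc2c(Nc3ccc(F)c(Cl)c3)ncnc2cc1O[C@H]1CCOC1`, is the starting point. In a functional assay on HeLa cells (Homo sapiens) for cytotoxicity, read by MTT assay, with a stated time of 72 h (a lower number here means a stronger inhibitor, a higher number a weaker inhibitor), compound 1 gives 27400 nM, the highest of the two numbers available. Its nearest neighbour is compound 2, `COc1ccc(/C=C/C(=O)Nc2cc3c(Nc4ccc(F)c(Cl)c4)ncnc3cc2O[C@H]2CCOC2)c(OC)c1`, which in this assay gives 26500 nM; the step of a 1.0-fold lower number from compound 1 to compound 2 (0.01 log units; within the scatter) lies within the scatter. Compound 3, `N#Cc1ccc(/C=C/C(=O)Nc2cc3c(Nc4ccc(F)c(Cl)c4)ncnc3cc2O[C@H]2CCOC2)cc1`, has no result in this assay: for compound 3 the entry reads "not determined" (no result reported). Compound 4, `O=C(/C=C/c1ccc(Br)cc1)Nc1cc2c(Nc3ccc(F)c(Cl)c3)ncnc2cc1O[C@H]1CCOC1`, differs from compound 1 in a single place: bromo in place of nitro on an aromatic carbon. Among the compounds with values here, no measured step swaps nitro for bromo. Within the data shown here, the only measured step, the one from compound 1 to compound 2, exchanges the whole 4-nitrophenyl for 2,4-dimethoxyphenyl at the same end of the molecule and leaves the number essentially unchanged, so the far smaller exchange of one group on that phenyl gives no reason to expect a shift beyond the scatter. Compound 4 is therefore expected at about 27000 nM, between 12000 nM and 60000 nM, which means an expected step of a 1.0-fold lower number from compound 1 to compound 4 (0.01 log units; within the scatter).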

Compound 4, half-maximal inhibitory concentration: 27500 nM
Beside the measured number, compound 4's estimate is 1.0-fold (0.01 log units) below it, within the range that was stated.
By their numbers in this assay, from the lowest: compounds 2, 1 and 4 (each within the scatter of the next).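

With bromo in place of nitro on an aromatic carbon, para to a large group, this assay shows a 1.0-fold higher number from compound 1 to compound 4 (0.00 log units; within the scatter), so at this position a nitro with 2 hydrogen-bond acceptors and a bromo with 0 cannot be told apart. The 4-bromophenyl also cannot be told apart from the 2,4-dimethoxyphenyl, with a 1.0-fold higher number from compound 2 to compound 4 (0.02 log units; within the scatter), which places all three measured phenyl ends within the scatter of one another. No measurement offered here accounts for this sameness.

From the compounds shown here alone, what an amine or a carboxylic acid on this phenyl ring would do to the number remains open. The compounds with numbers also all keep the same double-bonded chain and the shared core, so the effect of a longer chain in that part of the molecule is open too.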